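The source may report more compounds than this note shows. Statements on the series, on what has been measured and on what is new or still open speak of the compounds shown alone.

Three close relatives share one core and differ only in the chain attached through an oxygen to the aromatic ring. Compound 1 `COc1cc(C(C)(C)C)ccc1C/N=C(\S)NCc1ccc(NS(C)(=O)=O)cc1` gives 2400 nM in a functional assay for inhibition of Vanilloid receptor (Rattus norvegicus); on this read-out higher numbers stand for weaker inhibition and lower numbers for stronger inhibition. Compound 2 `CCCOc1cc(C(C)(C)C)ccc1C/N=C(\S)NCc1ccc(NS(C)(=O)=O)cc1` gives 250 nM in this assay, and compound 3 `CCCCCCOc1cc(C(C)(C)C)ccc1C/N=C(\S)NCc1ccc(NS(C)(=O)=O)cc1` gives 150 nM. Compound 3 therefore holds the lowest number of the three, separated from compound 2 by a gap that stays within the scatter and from compound 1 by a clear margin. The steps of a 9.6-fold lower number from compound 1 to compound 2 (0.98 log units; beyond the scatter) and a 16-fold lower number from compound 1 to compound 3 (1.20 log units; beyond the scatter) show that lengthening the chain from its smallest version clearly lowers the number, whereas a 1.7-fold lower number from compound 2 to compound 3 (0.22 log units; within the scatter) shows that adding further length beyond that point changes little. Compound 4 `CC(C)(C)COc1cc(C(C)(C)C)ccc1C/N=C(\S)NCc1ccc(NS(C)(=O)=O)cc1` takes the next step: tert-butyl in place of pentyl on a saturated chain carbon bound to an oxygen on an aromatic ring. Cut one bond further out, the same change reads as hexyl to neopentyl. This swaps one short chain for another, branched one at the same place, and the step most like it in size, a 1.7-fold lower number from compound 2 to compound 3 (0.22 log units; within the scatter), stayed within the scatter. In this assay compound 4 is therefore expected to show a 1.5-fold higher number from compound 3 to compound 4 (0.17 log units; within the scatter). For compound 4 the estimate is 220 nM, with a likely range from 80 nM to 600 nM.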

Compound 4, half-maximal inhibitory concentration: 60 nM
Beside the measured number, compound 4's estimate is 3.7-fold (0.56 log units) above it, outside the stated range (below it).
By their numbers in this assay, from the lowest: compound 4; then compounds 3 and 2 (each within the scatter of the next); then compound 1.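

Among the straight chains, going past the length in compound 2 gave no step beyond the scatter, yet at this same place, on a saturated chain carbon bound to an oxygen on an aromatic ring, this assay shows a 2.5-fold lower number from compound 3 to compound 4 (0.40 log units; beyond the scatter), even though neopentyloxy holds fewer carbons than hexyloxy, so in this small set chain length alone does not set the number. The branched group also stands clear of the shorter straight chain, with a 4.2-fold lower number from compound 2 to compound 4 (0.62 log units; beyond the scatter), and the span from the smallest chain widens to a 40-fold lower number from compound 1 to compound 4 (1.60 log units; beyond the scatter), a larger step than either straight chain gave from that same starting point. Nothing available here speaks to the reason for these gaps.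

Open still is whether the gain belongs to the tert-butyl end itself or to branching in general, which a related chain such as isobutyl or a cyclohexylmethyl group at this place could help to separate. Also open, on these data alone, is how the number responds when the chain end carries an amine or a carboxylic acid rather than plain carbon.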